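Trading a benzimidazole arm for a bare ethynyl group

The source may hold more compounds than are shown below. What is called first, only, known or untested is meant among the compounds shown, and "the series" means these compounds.

In a functional assay on BGC-823 cells (Homo sapiens) for inhibition, read by MTT assay, with a stated time of 72 h (on this read-out higher numbers stand for weaker inhibition and lower numbers for stronger inhibition), compound 1, with the structure `Cc1cc(N2CC[C@@H](C)[C@@H](N(C)c3ncnc4[nH]ccc34)C2)n2nc(SCc3nc4ccccc4[nH]3)nc2n1`, reaches only the assay's limit, reported as > 100000 nM, so its number is not known. Compound 2, `Cc1cc(N2CC[C@@H](C)[C@@H](N(C)c3ncnc4[nH]ccc34)C2)n2nc(SCc3csc4ccc(Cl)cc34)nc2n1`, likewise sits at a limit, > 100000 nM. For the measured compounds named here, compound 3, `C=CCSc1nc2nc(C)cc(N3CC[C@@H](C)[C@@H](N(C)c4ncnc5[nH]ccc45)C3)n2n1`, is the one compound with a measured number, 40900 nM. The change between the two limit compounds, a step that the two limits leave unreadable from compound 1 to compound 2, cannot be read, because both sit at the limit of > 100000 nM in this assay, at which 2 of the 3 values shown sit. Replacing the large group by the small vinyl group gives an at least 2.4-fold lower number from compound 1 to compound 3 (0.38 log units; beyond the scatter) and an at least 2.4-fold lower number from compound 2 to compound 3 (0.38 log units; beyond the scatter). Compound 4, `C#CSc1nc2nc(C)cc(N3CC[C@@H](C)[C@@H](N(C)c4ncnc5[nH]ccc45)C3)n2n1`, has not been measured; it differs from compound 1 by ethynyl in place of (1H-benzimidazol-2-yl)methyl on a sulfur. Ethynyl is, like vinyl, a small unsaturated group, so the move from compound 1 to compound 4 is expected to resemble the step to compound 3, improving beyond the scatter. Compound 4 is therefore estimated at 40000 nM, most likely between 15000 nM and 120000 nM. That estimate means a step of an at least 2.5-fold lower number from compound 1 to compound 4 (0.39 log units; beyond the scatter).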

Compound 4, half-maximal inhibitory concentration: 62100 nM
Compound 4: the middle estimate sits 1.6-fold (0.19 log units) below what was measured; the range from low to high includes it.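

With ethynyl on the sulfur, a second small group gives a measured number where the two large arms gave only a limit, with an at least 1.6-fold lower number from compound 1 to compound 4 (0.20 log units; that floor lies within the scatter) and an at least 1.6-fold lower number from compound 2 to compound 4 (0.20 log units; that floor lies within the scatter). Allyl and ethynyl on this sulfur cannot be told apart, with a 1.5-fold higher number from compound 3 to compound 4 (0.18 log units; within the scatter), so the swap of one small unsaturated group for the other changes nothing that can be read. The true size of the steps away from the large arms stays unknown because compounds 1 and 2 carry a limit and not a number: the limit of > 100000 nM in this assay, at which 2 of the 4 values shown sit.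

Going by these compounds, what remains open is whether any other group on this sulfur would move the number beyond the scatter around compounds 3 and 4. A plain methyl, a longer chain such as butyl, or a chain ending in an amine or a carboxylic acid could each test this.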